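The source may hold more compounds than are shown below. What is called first, only, known or untested is meant among the compounds shown, and "the series" means these compounds.

Three compounds share one core and were tested in a functional assay on HT-1080 cells (Homo sapiens) for antiproliferative activity, read by sulforhodamine B assay, with a stated time of 48 h; a lower number here means a stronger inhibitor, a higher number a weaker inhibitor. Compound 1 `Nc1ccc(S(=O)(=O)Nc2ccnc3cc(C(F)(F)F)ccc23)cc1` gives 29600 nM in this assay. Compound 2 `O=C(Nc1ccccc1)Nc1ccc(S(=O)(=O)Nc2ccnc3cc(C(F)(F)F)ccc23)cc1` gives 25400 nM in this assay. Among the compounds with values here, the only single-point step among the measured compounds, a 1.2-fold lower number from compound 1 to compound 2 (0.07 log units; within the scatter), lies within the scatter of repeated measurements. Compound 3 `O=S(=O)(Nc1nccs1)c1ccc(N/C(S)=N\c2ccnc3cc(C(F)(F)F)ccc23)cc1` gives 27300 nM in this assay; its number sits within the scatter of both compound 1 and compound 2, so the three measured compounds cannot be separated from one another on these data.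

Compound 4 `COc1cc(NS(=O)(=O)c2ccc(N/C(S)=N\c3ccnc4cc(C(F)(F)F)ccc34)cc2)nc(OC)n1` has not yet been measured. It differs from compound 3 in one place: 2,6-dimethoxypyrimidin-4-yl in place of 1,3-thiazol-2-yl on a sulfonamide nitrogen. Within the data shown here, no measured step touches the sulfonamide nitrogen; the one known step, a 1.2-fold lower number from compound 1 to compound 2 (0.07 log units; within the scatter), sits on a different nitrogen and stayed within the scatter. Nothing in the measured compounds therefore points to a step beyond the scatter in this assay. Compound 4 is expected to give 27000 nM, with a range from 9000 nM to 80000 nM. The step of a 1.0-fold lower number from compound 3 to compound 4 (0.00 log units; within the scatter) is expected to stay within the scatter.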

Compound 4, half-maximal inhibitory concentration: 29500 nM
Compound 4: middle estimate off by 1.1-fold (0.04 log units), on the low side; measured number inside the range.
By their numbers in this assay, from the lowest: compounds 2, 3, 4 and 1 (each within the scatter of the next).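

The step from a five-membered to a six-membered aromatic ring on the sulfonamide nitrogen, with 2,6-dimethoxypyrimidin-4-yl in place of 1,3-thiazol-2-yl, gives a 1.1-fold higher number from compound 3 to compound 4 (0.03 log units; within the scatter) in this assay. Within the data shown here, this is the first measured change at this position, and it shows that exchanging the ring for a larger one with more hydrogen-bond acceptors does not move the number beyond the scatter. No measurement shown here explains this lack of separation.

Going by these compounds, only these two aromatic rings have been compared at this position, so it remains open whether a plain hydrogen, a methyl group or a ring carrying a carboxylic acid or an amine would give a number beyond the scatter. On these data alone, it also remains open whether the same exchange would behave alike on a compound with a different remainder.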